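Replacing 4-hydroxyphenyl with 3,4-dimethoxyphenyl in the series

The source may hold more compounds than are shown below. What is called first, only, known or untested is meant among the compounds shown, and "the series" means these compounds.

In a functional assay on PC-3 cells (Homo sapiens) for cytotoxicity, read by sulforhodamine B assay, with a stated time of 48 h (a higher number here means a weaker inhibitor, a lower number a stronger inhibitor), compound 2 (`C[C@H]1CC[C@@H]2[C@@H](OC(=O)[C@]23CC(c2ccc(O)cc2)=NO3)[C@]2(C)C(=O)C=C[C@@]12O`) gives 20000 nM, the lower of two numbers, against 51000 nM for compound 1 (`C[C@H]1CC[C@@H]2[C@@H](OC(=O)[C@]23CC(c2ccccc2Br)=NO3)[C@]2(C)C(=O)C=C[C@@]12O`). Compound 3 (`COc1ccc(C2=NO[C@]3(C2)C(=O)O[C@@H]2[C@H]3CC[C@H](C)[C@]3(O)C=CC(=O)[C@@]23C)cc1OC`) carries 3,4-dimethoxyphenyl in place of 4-hydroxyphenyl on a carbon with a double bond to nitrogen. Among the measured compounds shown here, the only measured step at this place, a 2.6-fold lower number from compound 1 to compound 2 (0.41 log units; beyond the scatter), is modest and starts from a different group, so it offers a loose guide. A small move towards a higher number is expected in this assay. The expected change is a 1.5-fold higher number from compound 2 to compound 3 (0.18 log units; within the scatter), not beyond the scatter. Compound 3 is estimated at 30000 nM, within a range of 12000 nM to 70000 nM.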

Compound 3, half-maximal inhibitory concentration: 25000 nM
The estimate for compound 3 lay 1.2-fold (0.08 log units) above the measured number; the range from low to high includes it.
By their numbers in this assay, from the lowest: compounds 2 and 3 (each within the scatter of the next); then compound 1.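

In this assay, 3,4-dimethoxyphenyl in place of 4-hydroxyphenyl gives a 1.3-fold higher number from compound 2 to compound 3 (0.10 log units; within the scatter), so at this place a hydrogen-bond donor on the aromatic ring is not required to hold the number. 3,4-Dimethoxyphenyl in place of 2-bromophenyl gives a 2.0-fold lower number from compound 1 to compound 3 (0.31 log units; beyond the scatter), a modest step that puts both oxygen-bearing groups apart from 2-bromophenyl. No measurement is available that accounts for either step. As far as these compounds go, whether an amine or a carboxylic acid on the aromatic ring would shift the number remains open. So does the effect of a longer chain in place of the ring.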